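Swapping a sulfonamide for a methylpyrazole on the shared core

The source may hold more compounds than are shown below. What is called first, only, known or untested is meant among the compounds shown, and "the series" means these compounds.

Compound 3, `CS(=O)(=O)Nc1cccc2c1CCC2c1ncc[nH]1`, stands highest of the three compounds measured in a functional assay on CHO cells for agonist activity at Alpha-1A adrenergic receptor (Homo sapiens), read by FLIPR and calcium flux; on this read-out higher numbers stand for larger maximal responses and lower numbers for smaller maximal responses: compound 3 gives 87%, compound 2, `COc1cccc2c1CCC2c1ncc[nH]1`, gives 65%, and compound 1, `Cn1ccc(-c2cccc3c2CCC3c2ncc[nH]2)n1`, gives 19%. The step of a number 22 percentage points higher from compound 2 to compound 3 (beyond the scatter) was modest, while the step of a number 68 percentage points higher from compound 1 to compound 3 (beyond the scatter) was large. Compound 4, `Cn1cc(-c2cccc3c2CCC3c2ncc[nH]2)cn1`, differs from compound 3 in one place: 1-methyl-1H-pyrazol-4-yl in place of methanesulfonamido on an aromatic carbon. The step that bears most on this change is a number 68 percentage points higher from compound 1 to compound 3 (beyond the scatter), run in reverse, since compound 1 also carries a methylpyrazole ring where compound 4 does, though joined through a different ring atom. A large fall in this assay is therefore expected, giving the estimated step of a number 57 percentage points lower from compound 3 to compound 4 (beyond the scatter). Compound 4 is thus expected to reach 30%, within a range of 10% to 60%.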

Compound 4, largest response reached (Emax), in percent of the reference or control that the assay uses: 12%
Estimate against measurement, compound 4: 18 percentage points above; measured number inside the range.
By their numbers in this assay, from the lowest: compounds 4 and 1 (each within the scatter of the next); then compound 2; then compound 3.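

The 1-methyl-1H-pyrazol-3-yl and 1-methyl-1H-pyrazol-4-yl groups cannot be told apart in this assay, where the step reads a number 7 percentage points lower from compound 1 to compound 4 (within the scatter). The low response therefore does not depend on which ring atom joins the methylpyrazole to the shared core. Both other groups stand clear of the new one, with a number 75 percentage points lower from compound 3 to compound 4 (beyond the scatter) and a number 53 percentage points lower from compound 2 to compound 4 (beyond the scatter).

Nothing available explains why these groups give such different responses. As far as these compounds go, whether a plain amine or a carboxylic acid at this aromatic carbon would approach methanesulfonamido remains open.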